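Trimming the chain on the shared core: allyl to methyl

The compounds below may be only part of what the source reports. "The series", "measured", "known", "first", "only" and "open" are said of these compounds alone.

Compound 1, `COc1ccc(-c2cc(=O)n(CC(C)C)nc2-c2ccc(OC)cc2)cc1`; in a functional assay on HL-60 cells (Homo sapiens) for inhibition (a lower number here means a stronger inhibitor, a higher number a weaker inhibitor), only a limit: > 100000 nM
Compound 2, `C=CCn1nc(-c2ccc(OC)cc2)c(-c2ccc(OC)cc2)cc1=O`; in this assay only a limit: > 100000 nM

Going by the values given here, compound 2 stands at a limit in this assay, not at a number, and the one step measured so far, a step that the two limits leave unreadable from compound 1 to compound 2, therefore cannot be read. Both values sit at the limit of > 100000 nM in this assay, at which 2 of the 2 values shown sit. Compound 3, `COc1ccc(-c2cc(=O)n(C)nc2-c2ccc(OC)cc2)cc1`, differs from compound 2 by hydrogen in place of vinyl on a saturated chain carbon bound to an aromatic nitrogen. Among the compounds with values here, no measured step bears on this change, so no direction can be expected from the data. Compound 3 is therefore expected to remain near the limit, with a number no higher from compound 2 to compound 3 (the limit leaves the size open) as the estimated step and 100000 nM (30000 nM to 300000 nM) as the estimate.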

Compound 3, half-maximal inhibitory concentration: 1130 nM
Compound 3: the middle estimate sits 88-fold (1.95 log units) above what was measured, and the stated range ends above it.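

In this assay this position can clearly move the read-out: hydrogen in place of vinyl gives an at least 88-fold lower number from compound 2 to compound 3 (1.94 log units; beyond the scatter) and hydrogen in place of isopropyl gives an at least 88-fold lower number from compound 1 to compound 3 (1.94 log units; beyond the scatter) on the same chain carbon. Both steps lie beyond the scatter, so the methyl compound separates from both compounds with longer chains, which the earlier pair could not show. The step between those two compounds still cannot be read, as each stands at a limit: the limit of > 100000 nM in this assay, at which 2 of the 3 values shown sit.

On these data alone, whether an ethyl chain keeps the number of compound 3 remains open. So does what an amine or a carboxylic acid on this chain would do.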